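This account rests on a few compounds, and the source may have more. Where it says the series, first, only, none or still open, it means among the compounds named here.

Compound 1 `C=C/C=C\[C@H](C)[C@H](OC(N)=O)[C@@H](C)[C@H](O)[C@@H](C)C/C(C)=C\[C@H](C)[C@@H](O)[C@@H](C)/C=C\CCc1ccc(C)c(F)c1`: 4000 nM
Compound 2 `C=C/C=C\[C@H](C)[C@H](OC(N)=O)[C@@H](C)[C@H](O)[C@@H](C)C/C(C)=C\[C@H](C)[C@@H](O)[C@@H](C)/C=C\CCc1cccc(Cl)c1`: 650 nM

Among the compounds with values here, in a functional assay on MCF7 cells (Homo sapiens) for cytotoxicity (on this read-out lower numbers stand for stronger inhibition and higher numbers for weaker inhibition), compound 2 gives 650 nM as the lower of the two numbers measured so far. Compound 3 `C=C/C=C\[C@H](C)[C@H](OC(N)=O)[C@@H](C)[C@H](O)[C@@H](C)C/C(C)=C\[C@H](C)[C@@H](O)[C@@H](C)/C=C\CCc1cccc(OC)c1` carries methoxy in place of chloro on an aromatic carbon and is otherwise unchanged. Within the data shown here, the only measured step bearing on this ring is a 6.2-fold lower number from compound 1 to compound 2 (0.79 log units; beyond the scatter) and it is modest. A smaller move towards a higher number in this assay is therefore expected, and the estimated step is a 1.5-fold higher number from compound 2 to compound 3 (0.19 log units; within the scatter) at most modest in size. In this read-out compound 3 is expected at 1000 nM with 300 nM to 3500 nM as the estimated range.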

Compound 3, half-maximal inhibitory concentration: 500 nM
For compound 3 the middle estimate is 2.0-fold (0.30 log units) above the measured one; the measured number falls inside the stated range.
By their numbers in this assay, from the lowest: compounds 3 and 2 (each within the scatter of the next); then compound 1.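

In this assay methoxy in place of chloro on an aromatic carbon gives a 1.3-fold lower number from compound 2 to compound 3 (0.11 log units; within the scatter) and so the two groups cannot be told apart at this position. With an 8.0-fold lower number from compound 1 to compound 3 (0.90 log units; beyond the scatter) alongside it, the drop from compound 1 is no longer seen with chloro alone, as 3-methoxyphenyl goes with it too. No measurement here gives a reason for either step.

On these data alone, whether an amine or a carboxylic acid at this position would keep the number stays open. So does whether the fluoro or the methyl of compound 1 accounts for its gap.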